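This account rests on a few compounds, and the source may have more. Where it says the series, first, only, none or still open, it means among the compounds named here.

In a functional assay on the whole organism for inhibition, with Rattus norvegicus as the target, with stated times of 1 h and 3.5 h, at a dose of 100 mg/kg by the oral route (on this read-out lower numbers stand for less inhibition and higher numbers for more inhibition at the one dose given (going by the name of the read-out)), compound 1 `Cc1ncc2c(n1)CCN(C)C2` gives 45%. Compound 2 `CN1CCc2nc(N)ncc2C1` returns only a limit of the assay, < 5%. Among the compounds with values here, the single measured step is a number at least 40 percentage points lower from compound 1 to compound 2 (beyond the scatter), a change on a different core than the one considered here. Compound 3 `CC(C)(C)c1nc(NC#N)ncc1-c1ccccc1` likewise returns only a limit of the assay, < 5%. Compound 3 therefore stands at the limit of < 5% in this assay, at which 2 of the 3 values shown sit, with no number of its own. Compound 4 `CNc1ncc(-c2ccccc2)c(C(C)(C)C)n1` differs from compound 3 by methyl in place of cyano on a nitrogen on an aromatic ring. Within the data shown here, no measured step touches this exchange, so no direction can be drawn for it, and the reading for compound 4 is expected to stay close to the limit, a step of a number at least 3 percentage points higher from compound 3 to compound 4 (that floor lies within the scatter) in this assay. The estimate for compound 4 is 8%, from 0% to 25%.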

Compound 4, a percentage reported as inhibition, in the whole organism at one dose (the size of the read-out at that dose, not a potency): 37%
For compound 4 the middle estimate is 29 percentage points below the measured one; the whole stated range lies below it.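

In this assay, methyl in place of cyano on a nitrogen on an aromatic ring gives a number at least 32 percentage points higher from compound 3 to compound 4 (beyond the scatter). Within the data shown here, this is the first sign that the group on this nitrogen matters on the shared core of compound 3 and compound 4. Compound 3 gives a limit of the assay, not a number: the limit of < 5% in this assay, at which 2 of the 4 values shown sit.

On these data alone, the true size of the step therefore stays open. Also open, as far as these compounds go, are how a longer chain such as ethyl, or an acetyl group, would read on this nitrogen, and whether the exchange would carry over to the core of compound 1.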